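Aryl swap on the ring nitrogen: outlook for compound 4

This account rests on a few compounds, and the source may have more. Where it says the series, first, only, none or still open, it means among the compounds named here.

The three measured compounds share one core and differ only in the ring carried on the nitrogen. In a functional assay on HL-60 cells (Homo sapiens) for cytotoxicity, read by MTT assay, with a stated time of 48 h (a higher number here means a weaker inhibitor, a lower number a stronger inhibitor), compound 1 `Fc1cccc(-c2nc(Nc3ccccc3)c3cc(F)ccc3n2)c1` gives 48300 nM, compound 2 `COc1ccc(Nc2nc(-c3cccc(F)c3)nc3ccc(F)cc23)cc1` gives 38600 nM, and compound 3 `Fc1cccc(-c2nc(Nc3ccc(Cl)cc3)c3cc(F)ccc3n2)c1` gives 45700 nM. Compound 2 lies within the scatter of both others: a 1.3-fold lower number from compound 1 to compound 2 (0.10 log units; within the scatter), and a 1.2-fold higher number from compound 2 to compound 3 (0.07 log units; within the scatter). Compound 4 `Fc1cccc(-c2nc(Nc3ccccc3Br)c3cc(F)ccc3n2)c1` has not been measured; relative to compound 2 the change is 2-bromophenyl in place of 4-methoxyphenyl on a nitrogen on an aromatic ring. For the measured compounds named here, the steps that bear on it, a 1.3-fold lower number from compound 1 to compound 2 (0.10 log units; within the scatter), a 1.1-fold lower number from compound 1 to compound 3 (0.02 log units; within the scatter) and a 1.2-fold higher number from compound 2 to compound 3 (0.07 log units; within the scatter), all touch the same ring and all fall within the scatter, so in this assay no step beyond the scatter is expected. Compound 4 is therefore estimated at 40000 nM, range 20000 nM to 80000 nM. The expected step is a 1.0-fold higher number from compound 2 to compound 4 (0.02 log units; within the scatter).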

Compound 4, half-maximal inhibitory concentration: > 50000 nM
Compound 4 ended at the assay's limit; the forecaster's own chance of this, stated with the estimate: 10%; at least 1.2-fold (0.09 log units) between middle value and limit.
By their numbers in this assay, from the lowest: compounds 2, 3 and 1 (each within the scatter of the next). At a limit, above all of these: compound 4.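

In this assay, compound 4 carries a limit of the assay, not a number: the limit of > 50000 nM in this assay, at which 1 of the 4 values shown sits. The steps to it are floors only, an at least 1.2-fold higher number from compound 2 to compound 4 (0.11 log units; that floor lies within the scatter), an at least 1.0-fold higher number from compound 3 to compound 4 (0.03 log units; that floor lies within the scatter) and an at least 1.0-fold higher number from compound 1 to compound 4 (0.01 log units; that floor lies within the scatter). Going by these compounds, with 2-bromophenyl on this nitrogen, the series therefore still shows no step beyond the scatter, although the true size of these steps remains unknown.

The groups shown on this nitrogen are phenyl, 4-methoxyphenyl, 4-chlorophenyl and 2-bromophenyl. Open, on these data alone, is how a ring bearing an amine or a carboxylic acid, or a longer chain in place of the ring, would read.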